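A few compounds are considered here, and "the series" means these few. Any claim that something is new, unique, unknown or untested is made for them only; others in the source may bear on it.

Compound 1 `CCn1c(/C=C2/C(=O)Nc3ccc(F)cc32)nc2ccccc21` and compound 2 `Cn1c(/C=C2/C(=O)Nc3ccc([N+](=O)[O-])cc32)nc2ccccc21` share a core and differ at two places, so their numbers can only be read side by side. In a functional assay on DU-145 cells (Homo sapiens) for cytotoxicity, read by MTT assay, with a stated time of 48 h (a higher number here means a weaker inhibitor, a lower number a stronger inhibitor), compound 1 gives 40600 nM. For compound 2 this assay reports only a limit, > 50000 nM, and that is where compound 2 stands: at the edge of what the assay resolves, as noted in the limit of > 50000 nM in this assay, at which 1 of the 2 values shown sits. Compound 3 `CCn1c(/C=C2/C(=O)Nc3ccc([N+](=O)[O-])cc32)nc2ccccc21` is not yet measured. It differs from compound 2 by methyl in place of hydrogen on a saturated chain carbon bound to an aromatic nitrogen. Going by the values given here, no measured pair shows the effect of this change on its own, and the one other compound measured sits close to the same edge. No step beyond the scatter is therefore expected, and compound 3 is expected to remain a weak inhibitor in this assay, with the step that the limit leaves unreadable from compound 2 to compound 3 taken as small and uncertain in direction. The estimate for compound 3 is 60000 nM, ranging from 25000 nM to 150000 nM.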

Compound 3, half-maximal inhibitory concentration: > 50000 nM
Compound 3 ended at the assay's limit; the forecaster's own chance of this, stated with the estimate: 60%; the middle value does not contradict the limit.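

With compound 3, the series gains its first pair that differs in one place only, as compound 1 and compound 3 both carry ethyl and differ only in nitro in place of fluoro on an aromatic carbon. In this assay, from the compounds shown here alone, that change gives an at least 1.2-fold higher number from compound 1 to compound 3 (0.09 log units; that floor lies within the scatter), which is only a floor, so the real size of the step remains unknown and no change beyond the scatter can be claimed. The step for methyl in place of hydrogen cannot be read, as both compounds on either side of it stand at a limit: the limit of > 50000 nM in this assay, at which 2 of the 3 values shown sit.

The compounds shown leave open whether methyl in that place changes the number at all. They also leave open whether an amine on the aromatic carbon, or a longer chain such as propyl on the aromatic nitrogen, would give a value clear of the limit.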